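From 3-methylphenyl to 2-bromo-6-methoxyphenyl at a shared limit

The compounds below may be only part of what the source reports. "The series", "measured", "known", "first", "only" and "open" are said of these compounds alone.

Compound 1 `Cc1oc(-c2ccc(Cl)c(Cl)c2)nc1CN1CCC(C(=O)NCCCN2C[C@H](C)C[C@H](C)C2)CC1` and compound 2 `Cc1cccc(-c2nc(CN3CCC(C(=O)NCCCN4C[C@H](C)C[C@H](C)C4)CC3)c(C)o2)c1` share a core and differ in one group on an aromatic carbon. In an ADME assay on microsomes from liver (Rattus norvegicus) for metabolic stability, read by LC-MS, using NADPH, at 37 degrees C (on this read-out lower numbers stand for a shorter-lived compound and higher numbers for a longer-lived compound), compound 1 gives > 0.5 h, which is a limit of the assay and not a number. Compound 2 gives > 0.5 h, which is also a limit and not a number. Compound 2 therefore has no exact place on the scale, and the whole record so far is the limit of > 0.5 h in this assay, at which 2 of the 2 values shown sit.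

Compound 3 `COc1cccc(Br)c1-c1nc(CN2CCC(C(=O)NCCCN3C[C@H](C)C[C@H](C)C3)CC2)c(C)o1` carries 2-bromo-6-methoxyphenyl in place of 3-methylphenyl on that same aromatic carbon: 2-bromo-6-methoxyphenyl in place of 3-methylphenyl on an aromatic carbon. Going by the values given here, the only measured step that bears on this change is a step that the two limits leave unreadable from compound 1 to compound 2. Since a step that the two limits leave unreadable from compound 1 to compound 2 offers no size to carry forward, no shift beyond the usual scatter is expected in this assay, and no direction is favoured. The expected step is a step that the limit leaves unreadable from compound 2 to compound 3. For compound 3 the estimated half-life is 0.7 h, with an expected range from 0.35 h to 1.5 h. Another result reported only as a limit is also expected to be likely.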

Compound 3, half-life: 0.0583 h
The estimate for compound 3 lay 12-fold (1.08 log units) above the measured number; the measured number lies below the stated range.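

The earlier limits could not show whether the group on this aromatic carbon matters, but the new result shows that it can: in this assay, 2-bromo-6-methoxyphenyl gives an at least 8.5-fold lower number from compound 2 to compound 3 (0.93 log units; beyond the scatter), and the comparison with 3,4-dichlorophenyl gives an at least 8.5-fold lower number from compound 1 to compound 3 (0.93 log units; beyond the scatter). Both steps are minimum sizes, as each starts from a compound with no exact place on the scale, so the full drop in half-life may be larger. Compound 3 is the only compound shown with an exact number, and the rest of the record remains a limit: the limit of > 0.5 h in this assay, at which 2 of the 3 values shown sit.

The step between the other two compounds cannot be read, so 3-methylphenyl and 3,4-dichlorophenyl cannot be placed in order, and neither can be said to give the longer half-life. Going by these compounds, compound 3 also brings in the bromine and the methoxy group together, so the effect of each alone stays open, and 2-bromophenyl and 2-methoxyphenyl at this same place on the shared core would be the groups that could separate them.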